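This account rests on a few compounds, and the source may have more. Where it says the series, first, only, none or still open, it means among the compounds named here.

Three compounds were measured in a functional assay on PC-3 cells (Homo sapiens) for cytotoxicity; a lower number here means a stronger inhibitor, a higher number a weaker inhibitor:

Compound 1, `COc1ccc2nc(NC(=O)CCCCCCC(=O)NO)sc2c1`: 1.56 ug/mL
Compound 2, `O=C(CCCCC(=O)Nc1nc2ccccc2s1)NO`: 12.5 ug/mL
Compound 3, `COc1ccc2nc(NC(=O)CCCCC(=O)NO)sc2c1`: 15.3 ug/mL

Compound 3 has the highest number of the three. Its nearest neighbour is compound 2, and the two lie within the scatter of each other, as the step of a 1.2-fold higher number from compound 2 to compound 3 (0.09 log units; within the scatter) shows. Compound 1 stands furthest away, and the step of a 9.8-fold higher number from compound 1 to compound 3 (0.99 log units; beyond the scatter) is beyond the scatter.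

Compound 4, `O=C(CCCCC(=O)Nc1nc2ccc([N+](=O)[O-])cc2s1)NO`, differs from compound 3 in one place: nitro in place of methoxy on an aromatic carbon. Of the measured steps, only a 1.2-fold higher number from compound 2 to compound 3 (0.09 log units; within the scatter) touches the same aromatic carbon, and it was within the scatter. Going by the values given here, no measured pair shows the nitro itself, so nothing in the data points to a change in either direction. For that reason the step of a 1.1-fold lower number from compound 3 to compound 4 (0.04 log units; within the scatter) is expected to stay within the scatter. Compound 4 is therefore estimated at 14 ug/mL in this assay, with a range from 6 ug/mL to 35 ug/mL.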

Compound 4, half-maximal inhibitory concentration: > 30 ug/mL
Compound 4 gave a limit, no number; the forecaster's own chance of this, stated with the estimate: 5%; middle value at least 2.1-fold (0.33 log units) away from the limit.
By their numbers in this assay, from the lowest: compound 1; then compounds 2 and 3 (each within the scatter of the next). At a limit, above all of these: compound 4.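

In this assay compound 4 gives only a limit, > 30 ug/mL, and not a number. Set against hydrogen on this aromatic carbon, nitro gives a change beyond the scatter, an at least 2.4-fold higher number from compound 2 to compound 4 (0.38 log units; beyond the scatter), whereas methoxy in place of hydrogen on the same carbon stayed within it, so this position is not indifferent to every group it carries. Set against methoxy, the step is an at least 1.9-fold higher number from compound 3 to compound 4 (0.29 log units; that floor lies within the scatter), so the floor alone does not separate nitro from methoxy.

As far as these compounds go, the true size of both steps stays open, since compound 4 sits at a limit: the limit of > 30 ug/mL in this assay, at which 1 of the 4 values shown sits. Also open, from the compounds shown here alone, is how an amine or a carboxylic acid on this carbon would read, and whether nitro has the same effect on the longer chain of compound 1.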